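A few compounds are considered here, and "the series" means these few. Any claim that something is new, unique, unknown or untested is made for them only; others in the source may bear on it.

In a functional assay on HeLa cells (Homo sapiens) for cytotoxicity, read by MTT assay (on this read-out lower numbers stand for stronger inhibition and higher numbers for weaker inhibition), compound 1 `COC(=O)C[C@H]1C[C@@H](O)[C@@H](C)[C@@H](c2ccc(C(C)C)cc2)N1` is recorded as "not active" (no number reported), so it has no single number. Compound 2 `COC(=O)C[C@H]1C[C@H](O)[C@@H](C)[C@@H](c2ccc(C(C)C)cc2)N1` gives 18200 nM, and what separates the pair is the fact that compounds 1 and 2 differ only in the configuration as drawn. Compound 3 `COC(=O)C[C@H]1C[C@@H](O)[C@@H](C)[C@@H](c2ccc(F)cc2)N1` keeps the configuration drawn for compound 1 and carries fluoro in place of isopropyl on an aromatic carbon, fluoro in place of isopropyl on an aromatic carbon, para to a large group. With compound 1 at "not active" (no number reported), only a modest step towards stronger inhibition is expected in this assay, and possibly none. The expected value for compound 3 is 40000 nM, with an estimated range from 12000 nM to 100000 nM.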

Compound 3, half-maximal inhibitory concentration: 19800 nM
Estimate against measurement, compound 3: 2.0-fold (0.31 log units) above; low and high end bracket the measured number.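

No step can be read from compound 1 to compound 3, as compound 1 stands only as "not active" (no number reported). The compounds shown leave open how far fluoro in place of isopropyl shifts cytotoxicity in either configuration.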